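The compounds below may be only part of what the source reports. "The series", "measured", "known", "first", "only" and "open" are said of these compounds alone.

Measured compounds in a functional assay on UACC-903 cells (Homo sapiens) for antiproliferative activity, read by MTT assay, with a stated time of 24 h; on this read-out higher numbers stand for weaker inhibition and lower numbers for stronger inhibition:

Compound 1 `CC(=O)Oc1ccccc1C(=O)NCC[Se]C#N` gives 24300 nM.
Compound 2 `CC(=O)Oc1ccccc1C(=O)OCC[Se]C#N` gives 33900 nM.
Compound 3 `CC(=O)Oc1ccccc1C(=O)[Se]CC[Se]C#N` gives only a limit of the assay, > 50000 nM.

All three share the same core and differ only in the group on the carbonyl carbon. For the measured compounds named here, for compound 3 the assay reports no number, only that its value lies at a limit (the limit of > 50000 nM in this assay, at which 1 of the 3 values shown sits). The step of an at least 2.0-fold higher number from compound 1 to compound 3 (0.31 log units; beyond the scatter) is beyond the scatter, while an at least 1.4-fold higher number from compound 2 to compound 3 (0.16 log units; that floor lies within the scatter) and a 1.4-fold higher number from compound 1 to compound 2 (0.14 log units; within the scatter) are not.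

Compound 4 `CC(=O)Oc1ccccc1C(=O)NCCSC#N` is not yet measured. It differs from compound 3 by a group of 6 heavy atoms (3 carbon, 2 nitrogen, 1 sulfur; no ring) in place of a group of 6 heavy atoms (3 carbon, 1 nitrogen, 2 selenium; no ring), on a carbonyl carbon. Part of that change, the return to an amide, is the reverse of the step from compound 1 to compound 3; the exchange of the selenium-bearing chain end for a sulfur-bearing one has no measured counterpart here. The expectation is therefore a lower number in this assay for compound 4 than the limit of compound 3, in the region where compound 1 sits, with wide uncertainty. Compound 4 is estimated at 30000 nM, with a range from 12000 nM to 80000 nM, which would be an expected step of an at least 1.6-fold lower number from compound 3 to compound 4 (0.22 log units; that floor lies within the scatter).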

Compound 4, half-maximal inhibitory concentration: > 50000 nM
Compound 4: no number, only a limit (the forecaster's own chance of this, stated with the estimate: 35%); middle value at least 1.6-fold (0.22 log units) away from the limit.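

Compound 4 stands at a limit of the assay, > 50000 nM, in this assay, and it shares that limit with compound 3: the limit of > 50000 nM in this assay, at which 2 of the 4 values shown sit.

The earlier compounds shown here varied only the group on the carbonyl carbon, whereas this change keeps the amide and replaces selenium with sulfur at the chain end, giving an at least 2.0-fold higher number from compound 1 to compound 4 (0.31 log units; beyond the scatter). For the compounds shown here, this is the first sign that the chain end itself counts, at least for the amide, while the other comparison, an at least 1.4-fold higher number from compound 2 to compound 4 (0.16 log units; that floor lies within the scatter), has a floor too small to add much.

The step between compound 3 and compound 4 cannot be read, as both carry only a limit. On these data alone, how far compound 4 lies past its limit stays open, as does whether a longer chain or a carboxylic acid in place of the nitrile would keep the activity of compound 1.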